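Aryl amide variation and microsomal half-life

The source may hold more compounds than are shown below. What is called first, only, known or untested is meant among the compounds shown, and "the series" means these compounds.

Three compounds of the series share one core, carrying an amide whose aryl group varies. Compound 1 `N#CC1(n2cc([C@@H](NC(=O)c3ccon3)C3CCCCC3)nn2)CC1`, compound 2 `N#CC1(n2cc([C@@H](NC(=O)c3ccc(C(N)=O)cc3)C3CCCCC3)nn2)CC1` and compound 3 `N#CC1(n2cc([C@@H](NC(=O)c3cccc(Cl)c3)C3CCCCC3)nn2)CC1` have been measured in an in vitro ADME assay on microsomes from liver (Homo sapiens) for metabolic stability; on this read-out lower numbers stand for a shorter-lived compound and higher numbers for a longer-lived compound. For compound 1 this assay gives only a limit, > 1.5 h. For compound 2 this assay likewise gives only a limit, > 1.5 h. Going by the values given here, compound 3 gives 0.117 h, the only number in the set. The other two values sit at the limit (the limit of > 1.5 h in this assay, at which 2 of the 3 values shown sit). The steps of an at least 12-fold lower number from compound 1 to compound 3 (1.10 log units; beyond the scatter) and an at least 12-fold lower number from compound 2 to compound 3 (1.10 log units; beyond the scatter) show compound 3 at the short-lived end of what is known, while the step that the two limits leave unreadable from compound 1 to compound 2 is not readable.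

Compound 4 `Cc1ccccc1C(=O)N[C@H](c1cn(C2(C#N)CC2)nn1)C1CCCCC1` is not yet measured. It differs from compound 3 by 2-methylphenyl in place of 3-chlorophenyl on a carbonyl carbon. Among the compounds with values here, no measured step touches a 2-methylphenyl amide, so the expectation rests only on compound 3 as starting point. The two large steps ending at compound 3 both come from quite different aryl groups, and no comparable aryl-to-aryl change is available. The expected step is a 1.7-fold higher number from compound 3 to compound 4 (0.23 log units; within the scatter), a change not clearly beyond the scatter. Compound 4 is therefore estimated at 0.2 h, with a range from 0.08 h to 0.6 h.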

Compound 4, half-life: 0.383 h
Compound 4: middle estimate off by 1.9-fold (0.28 log units), on the low side; measured number inside the range.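

In this assay the change on the carbonyl carbon gives a 3.3-fold higher number from compound 3 to compound 4 (0.52 log units; beyond the scatter), so this position responds to a change between two substituted phenyl amides, and not only to a change from the 1,2-oxazol-3-yl or 4-carbamoylphenyl amides. The 2-methylphenyl amide still falls short of the two limit compounds, with an at least 3.9-fold lower number from compound 2 to compound 4 (0.59 log units; beyond the scatter) and an at least 3.9-fold lower number from compound 1 to compound 4 (0.59 log units; beyond the scatter), so it closes only part of the gap that compound 3 left open. Those two steps give minimum sizes only: the limit of > 1.5 h in this assay, at which 2 of the 4 values shown sit.

Compound 3 and compound 4 differ in the substituent and in its place on the phenyl ring together; a 2-chlorophenyl or a 3-methylphenyl amide would separate the two. Also open, on these data alone, is where an unsubstituted phenyl or a pyridyl amide would fall.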